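Amide variation in a nitro methylsulfonyl benzamide series

The compounds below may be only part of what the source reports. "The series", "measured", "known", "first", "only" and "open" are said of these compounds alone.

Measured so far:
- compound 1 `CS(=O)(=O)c1ccc(C(=O)N2CCC(C(=O)N(Cc3ccccc3)c3ccccc3)CC2)cc1[N+](=O)[O-]`: in an assay on isolated protein for inhibition of thyroid hormone receptor alpha (Homo sapiens), read by fluorescence polarization (a higher number here means a weaker inhibitor, a lower number a stronger inhibitor), compound 1 gives > 60000 nM, which is a limit of the assay.
- compound 2 `CN(Cc1ccccc1)C(=O)C1CCN(C(=O)c2ccc(S(C)(=O)=O)c([N+](=O)[O-])c2)CC1`: in this assay compound 2 gives > 60000 nM, also a limit.
- compound 3 `CC1CCN(C(=O)CCCNC(=O)c2ccc(S(C)(=O)=O)c([N+](=O)[O-])c2)CC1`: in this assay compound 3 gives > 60000 nM, again a limit.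

Compound 2 stands at the limit of this assay; the two other values shown are limits as well, so every value in the series sits at the limit of > 60000 nM in this assay, at which 3 of the 3 values shown sit. For the measured compounds named here, the only step between measured compounds, a step that the two limits leave unreadable from compound 1 to compound 2, is methyl in place of phenyl on an amide-type nitrogen and cannot be read from two limits.

Compound 4 `CC1Cc2ccccc2N1C(=O)C1CCN(C(=O)c2ccc(S(C)(=O)=O)c([N+](=O)[O-])c2)CC1` differs from compound 2 by 2-methyl-2,3-dihydro-1H-indol-1-yl in place of benzyl(methyl)amino on a carbonyl carbon. Going by the values given here, no measured step bears on this change in a readable way, and no direction or size of effect can be taken from the series. With all three values at the limit of this assay, the step that the limit leaves unreadable from compound 2 to compound 4 is expected to be none beyond the scatter, with compound 4 most likely remaining at the limit. Compound 4 is estimated at 80000 nM in this assay, with a range from 20000 nM to 300000 nM.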

Compound 4, half-maximal inhibitory concentration: > 60000 nM
Compound 4 ended at the assay's limit; the forecaster's own chance of this, stated with the estimate: 85%; the middle value is on the limit's open side.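

No new step can be read from compound 2 to compound 4, as both stand at a limit in this assay: the limit of > 60000 nM in this assay, at which 4 of the 4 values shown sit.

The compounds shown leave open whether any change on the shared core gives a readable value in this assay, and how the four compounds rank.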